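The source may hold more compounds than are shown below. What is called first, only, known or untested is meant among the compounds shown, and "the series" means these compounds.

Measured compounds:
compound 1 `Cc1nc(S(C)(=O)=O)ccc1Oc1ncnc(OC2CCN(C(=O)SC(C)C)CC2)c1F` — 81% in a functional assay on isolated protein for inhibition of Glucose-dependent insulinotropic receptor (Rattus norvegicus), read by HTRF and cAMP accumulation; a higher number here means a larger maximal response, a lower number a smaller maximal response
compound 2 `Cc1nc(S(C)(=O)=O)ccc1Oc1ncnc(OC2CCN(C(=S)OC(C)C)CC2)c1F` — 47% in this assay

Compound 2 stands lowest of the two numbers in this assay; its nearest neighbour is compound 1, whose number is higher by a margin beyond the scatter. For the measured compounds named here, the only measured step, a number 34 percentage points lower from compound 1 to compound 2 (beyond the scatter), swaps one group on the amine nitrogen in the ring for another of the same size, and it was large.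

Compound 3 `Cc1nc(S(C)(=O)=O)ccc1Oc1ncnc(OC2CCN(C(=O)C(C)(F)F)CC2)c1F` differs from compound 2 at the same place: a group of 6 heavy atoms (3 carbon, 1 oxygen, 2 fluorine; no ring) in place of a group of 6 heavy atoms (4 carbon, 1 oxygen, 1 sulfur; no ring), on an amine nitrogen in a ring. Compound 3 carries a carbonyl on that nitrogen, as compound 1 does, whereas compound 2 does not, and the step from compound 1 to compound 2 shows how much a change here can move the maximal response. An upward step is therefore expected for compound 3, though its size is uncertain with one step to go on. The expected step is a number 27 percentage points higher from compound 2 to compound 3 (beyond the scatter). Compound 3 is estimated at 74%, within a range from 50% to 98%.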

Compound 3, largest response reached (reported as efficacy), in percent of the reference or control that the assay uses: 87%
Estimate against measurement, compound 3: 13 percentage points below; the range from low to high includes it.
By their numbers in this assay, from the lowest: compound 2; then compounds 1 and 3 (each within the scatter of the next).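

Compound 3 shows that the amine nitrogen in the ring can carry a group without sulfur and still keep a large maximal response in this assay: the change from the group of compound 2 to (1,1-difluoroethyl)carbonyl gives a number 40 percentage points higher from compound 2 to compound 3 (beyond the scatter), while 1,1-difluoroethyl in place of isopropylsulfanyl on the carbonyl carbon gives only a number 6 percentage points higher from compound 1 to compound 3 (within the scatter). Among these three compounds the two with a carbonyl on that nitrogen therefore lie within the scatter of each other, and compound 2, the only one without it, stands lowest. Nothing available explains the low response of compound 2.

The compounds shown leave open whether that low response goes with the thiocarbonyl or with its attached oxygen, a question that an isopropoxy group on the carbonyl carbon would separate. They also leave open how far the carbonyl carbon tolerates other groups, such as an amine or a trifluoromethyl.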